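Swapping chloro for fluoro on the aniline ring

A few compounds are considered here, and "the series" means these few. Any claim that something is new, unique, unknown or untested is made for them only; others in the source may bear on it.

The two measured compounds share one core and differ only in the groups on the aniline ring. Compound 1 `CN1CCN(CCCOc2cccc3nc(Nc4ccc(Cl)c(C(F)(F)F)c4)ccc23)CC1` is tested in a functional assay on cells (Panel melanoma (Carcinoma cell lines), Homo sapiens) for inhibition, read by sulforhodamine B assay, with a stated time of 48 h (on this read-out higher numbers stand for lower toxicity in this test and lower numbers for higher toxicity in this test), where compound 1 gives 6700 nM. Compound 2 `CN1CCN(CCCOc2cccc3nc(Nc4ccc(Cl)c(F)c4)ccc23)CC1` gives 6770 nM in the same test. Within the data shown here, the one measured step, a 1.0-fold higher number from compound 1 to compound 2 (0.00 log units; within the scatter), shows that the larger group and the smaller one give the same outcome. Among the numbers seen so far, compound 2 has the higher value, but its gap to compound 1 lies within the scatter, so no ordering between them can be claimed.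

Compound 3 `CN1CCN(CCCOc2cccc3nc(Nc4ccc(F)c(F)c4)ccc23)CC1` has not yet been measured. Its change from compound 2 is fluoro in place of chloro on an aromatic carbon, placed on an aromatic carbon ortho to a fluoro group and para to a large group. Among the measured compounds shown here, only the step from compound 1 to compound 2 bears on this swap, and it was flat. A halogen-for-halogen exchange on the same ring is therefore expected to move the number little, if at all, with no direction beyond the scatter. The step expected is a 1.1-fold higher number from compound 2 to compound 3 (0.04 log units; within the scatter). Compound 3 is estimated at 7500 nM, with a range from 3500 nM to 16000 nM.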

Compound 3, concentration lethal to 50% of the cells: 10500 nM
Beside the measured number, compound 3's estimate is 1.4-fold (0.15 log units) below it, and the stated range covers the measured number.
By their numbers in this assay, from the lowest: compounds 1, 2 and 3 (each within the scatter of the next).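

In this assay, fluoro in place of chloro on this aromatic carbon, ortho to a fluoro group and para to a large group, gives a 1.6-fold higher number from compound 2 to compound 3 (0.19 log units; within the scatter), so either halogen can sit at this position with no effect that stands clear of the scatter. This adds to the earlier step, which concerned the other substituent on the same ring: now both substituents have been exchanged singly, and neither exchange has given a real difference. The combined exchange, 3,4-difluorophenyl in place of 4-chloro-3-(trifluoromethyl)phenyl, gives a 1.6-fold higher number from compound 1 to compound 3 (0.20 log units; within the scatter), so altering the two places together also stays within the scatter, and nothing measured here offers an explanation for this flat picture.

Going by these compounds, all three compounds carry halogens or trifluoromethyl on this ring, so it remains open whether a quite different group on the same carbon, such as an amine, a methoxy group or a carboxylic acid, would move the number beyond the scatter. On these data alone, it also remains open whether these halogen exchanges would stay as flat in a test on other cell lines.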